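The compounds below may be only part of what the source reports. "The series", "measured", "known", "first", "only" and "open" are said of these compounds alone.

The measured compounds are compound 1 `COc1cccc(CNc2ncnc3c2ncn3[C@@H]2O[C@H](CO)[C@@H](O)[C@H]2O)c1`, which in a functional assay on CCRF-CEM cells (Homo sapiens) for antiproliferative activity, with a stated time of 72 h (a higher number here means a weaker inhibitor, a lower number a stronger inhibitor), gives 7600 nM, and compound 2 `COc1ccc(CNc2ncnc3c2ncn3[C@@H]2O[C@H](CO)[C@@H](O)[C@H]2O)c(OC)c1`, which in this assay gives > 166000 nM.

The value of compound 2 is a limit of the assay and not a number, so compound 2 stands only at the limit of > 166000 nM in this assay, at which 1 of the 2 values shown sits. Within the data shown here, the single measured step is an at least 21-fold higher number from compound 1 to compound 2 (1.33 log units; beyond the scatter). Compound 3 `Cc1ccc(O)c(CNc2ncnc3c2ncn3[C@@H]2O[C@H](CO)[C@@H](O)[C@H]2O)c1` differs from compound 2 by 2-hydroxy-5-methylphenyl in place of 2,4-dimethoxyphenyl on a saturated chain carbon bound to a nitrogen on an aromatic ring. The measured step concerns a different exchange of the aromatic group on the same saturated chain carbon, so it bears on the new step only by showing that this aromatic group can move the number strongly. Because compound 2 sits at the limit of > 166000 nM in this assay, at which 1 of the 2 values shown sits, the step in this assay can only be estimated as downward or none, and the expected step is an at least 5.5-fold lower number from compound 2 to compound 3 (0.74 log units; beyond the scatter). Compound 3 is thus expected to give about 30000 nM, in the range 5000 nM to 166000 nM.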

Compound 3, half-maximal inhibitory concentration: 1900 nM
Compound 3: middle estimate off by 16-fold (1.20 log units), on the high side; measured number below the stated range.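

In this assay, the aromatic group on the saturated chain carbon bound to a nitrogen on an aromatic ring can also lower the number, not only raise it: 2-hydroxy-5-methylphenyl brings a 4.0-fold lower number from compound 1 to compound 3 (0.60 log units; beyond the scatter). The exchange of 2,4-dimethoxyphenyl for the same group brings an at least 87-fold lower number from compound 2 to compound 3 (1.94 log units; beyond the scatter), which shows that the two compounds lie far apart. Compound 2 gives > 166000 nM, which is a limit and not a number, so this step gives only a bound on its size: the limit of > 166000 nM in this assay, at which 1 of the 3 values shown sits.

As far as these compounds go, the hydroxy and methyl groups enter together in compound 3, so it remains open which of them carries the step. From the compounds shown here alone, it also remains open how an amine or a carboxylic acid on this aromatic group would read in this assay.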